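Changing one fluoro group: an estimate for compound 4

The compounds below may be only part of what the source reports. "The series", "measured", "known", "first", "only" and "open" are said of these compounds alone.

- Compound 1 `CCCCCC1(O)C(=O)Nc2ccc(Nc3ccc(F)cc3)cc21` gives > 100000 nM as a limit of the assay, not a number
- Compound 2 `CC(C)CCC1(O)C(=O)Nc2ccc(Nc3ccc(F)cc3)cc21` gives 16800 nM in the same test
- Compound 3 `O=C1Nc2ccc(Nc3ccc(F)cc3)cc2C1(O)Cc1ccccc1` gives 18100 nM in the same test

These values come from a functional assay on NCI-H460 cells (Homo sapiens) for antiproliferative activity, read by MTT assay, with a stated time of 48 h (a lower number here means a stronger inhibitor, a higher number a weaker inhibitor), and the three compounds share one core. Within the data shown here, compound 2 has only one true number to be set against, and it stands level with that number. The gap is a 1.1-fold higher number from compound 2 to compound 3 (0.03 log units; within the scatter) and offers no ranking.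

Compound 4 `CC(C)CCC1(O)C(=O)Nc2ccc(Nc3ccc(C(F)(F)F)cc3)cc21` keeps the isobutyl chain of compound 2 and alters one group elsewhere: trifluoromethyl in place of fluoro on an aromatic carbon, para to a large group.

Among the measured compounds shown here, no measured step touches that group. All of them alter the chain, and the two beyond the scatter are an at least 5.9-fold lower number from compound 1 to compound 2 (0.77 log units; beyond the scatter) and an at least 5.5-fold lower number from compound 1 to compound 3 (0.74 log units; beyond the scatter). They show that this assay can respond to a change in the molecule, but they give neither size nor direction for this new change. A step beyond the scatter is therefore not expected, though a larger one remains possible.

The expected step is a 1.1-fold lower number from compound 2 to compound 4 (0.05 log units; within the scatter) in size.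

Compound 4 is estimated at 15000 nM, with an expected range from 5000 nM to 45000 nM in this test.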

Compound 4, half-maximal inhibitory concentration: 17200 nM
The estimate for compound 4 lay 1.1-fold (0.06 log units) below the measured number, and the stated range covers the measured number.
By their numbers in this assay, from the lowest: compounds 2, 4 and 3 (each within the scatter of the next). At a limit, above all of these: compound 1.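

Until now, every measured step altered the chain on the shared core, so this assay had given no reading on the aromatic carbon that carries the fluoro group, and the chain was the only part seen to move the number. With the isobutyl chain held fixed, placing trifluoromethyl instead of fluoro on that aromatic carbon, para to a large group, gives a 1.0-fold higher number from compound 2 to compound 4 (0.01 log units; within the scatter), so the two compounds stand level and this swap, at this one place, has no effect that the test can tell from scatter. Nothing measured here says why the two groups read alike.

The compounds shown leave open whether a different group on this aromatic carbon, such as an amine, a nitrile or a carboxylic acid, would give a step beyond the scatter, or whether removing the fluoro group altogether would do so. They also leave open whether trifluoromethyl would read the same when paired with the chain of compound 1 or of compound 3, since this single pair shares the isobutyl chain.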